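The source may hold more compounds than are shown below. What is called first, only, known or untested is meant among the compounds shown, and "the series" means these compounds.

Compound 1 `N#Cc1ccc(Nc2nc(Oc3ccnc4ccccc34)nc(N3CCN(c4ccc(F)cc4)CC3)n2)cc1C(F)(F)F`: in a functional assay on DU-145 cells (Homo sapiens) for cytotoxicity, read by sulforhodamine B assay, with a stated time of 48 h (on this read-out lower numbers stand for higher toxicity in this test and higher numbers for lower toxicity in this test), compound 1 gives > 100000 nM, which is a limit of the assay and not a number.
Compound 2 `CC(=O)N1CCN(c2nc(Nc3ccc(C#N)c(C(F)(F)F)c3)nc(Oc3ccnc4ccccc34)n2)CC1`: in this assay compound 2 gives > 100000 nM, again a limit of the assay.
Compound 3 `N#Cc1ccc(Nc2nc(Oc3ccnc4ccccc34)nc(N3CCN(C(c4ccccc4)c4ccccc4)CC3)n2)cc1C(F)(F)F`: in this assay compound 3 gives > 100000 nM, also a limit of the assay.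

The three compounds share one core and differ only in the group on an amine nitrogen in a ring: 4-fluorophenyl in compound 1, acetyl in compound 2, and a third group in compound 3. Compound 2 therefore stands where every measured compound stands, at a limit, and the two further values shown are limits as well (the limit of > 100000 nM in this assay, at which 3 of the 3 values shown sit). Within the data shown here, the one step between measured compounds that touches this position, a step that the two limits leave unreadable from compound 1 to compound 2, is unreadable in size because both ends sit at the limit (the limit of > 100000 nM in this assay, at which 3 of the 3 values shown sit).

Compound 4 `CC(C)N1CCN(c2nc(Nc3ccc(C#N)c(C(F)(F)F)c3)nc(Oc3ccnc4ccccc34)n2)CC1` is the next variation at the same position: isopropyl in place of acetyl on an amine nitrogen in a ring. Among the measured compounds shown here, no measured step gives a readable size for a change there, so no shift beyond the scatter can be expected from compound 2 to compound 4 in this assay; the expected step is a step that the limit leaves unreadable from compound 2 to compound 4. Compound 4 is accordingly estimated at 150000 nM, within 40000 nM to 600000 nM, most likely reported only as a limit again.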

Compound 4, concentration lethal to 50% of the cells: > 100000 nM
Compound 4 was reported as a limit (the forecaster's own chance of this, stated with the estimate: 75%); the middle value lies beyond the limit too.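

Neither the step to compound 4 from compound 2 nor the step to it from compound 1 can be read, because compound 4 also gives only a limit in this assay: the limit of > 100000 nM in this assay, at which 4 of the 4 values shown sit. The compounds shown leave open where the true value of any of them lies and whether any group on this amine nitrogen changes the read-out.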